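The source may report more compounds than this note shows. Statements on the series, on what has been measured and on what is new or still open speak of the compounds shown alone.

Measured so far in a functional assay on LNCaP cells (Homo sapiens) for antiproliferative activity, read by CCK-8 assay, with a stated time of 6 days; on this read-out lower numbers stand for stronger inhibition and higher numbers for weaker inhibition:
compound 1 `CC(=O)c1ccc(C(=O)N[C@@H](C)Cn2ccc(-c3ccc(C#N)c(Cl)c3)n2)cc1` gives 3600 nM;
compound 2 `CC(Cn1ccc(-c2ccc(C#N)c(Cl)c2)n1)C(=O)Nc1cc[nH]n1` gives > 30000 nM, a limit of the assay, not a number;
compound 3 `CC(Cn1ccc(-c2ccc(C#N)c(Cl)c2)n1)C(=O)Nc1cccc(C(C)O)c1` gives 4150 nM.

Compound 3 holds the highest of the two numbers; compound 1 sits within the scatter of it, so no order between the two is claimed. Compound 4 `CC(=O)c1cccc(NC(=O)C(C)Cn2ccc(-c3ccc(C#N)c(Cl)c3)n2)c1` differs from compound 3 by acetyl in place of 1-hydroxyethyl on an aromatic carbon. The only measured step, an at least 7.2-fold lower number from compound 2 to compound 3 (0.85 log units; beyond the scatter), concerns the group on the amide nitrogen as a whole, not the substituent on the phenyl ring, so it bears on this change only loosely; no shown step varies the substituent on that ring. Compound 4 is therefore expected to stay close to compound 3, with a 1.0-fold lower number from compound 3 to compound 4 (0.02 log units; within the scatter) not beyond the scatter. Compound 4 is estimated at 4000 nM, range 1500 nM to 11000 nM.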

Compound 4, half-maximal inhibitory concentration: 1540 nM
Compound 4: middle estimate off by 2.6-fold (0.41 log units), on the high side; the range from low to high includes it.
By their numbers in this assay, from the lowest: compound 4; then compounds 1 and 3 (each within the scatter of the next). At a limit, above all of these: compound 2.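

In this assay the substituent on the phenyl ring now proves to matter, with a 2.7-fold lower number from compound 3 to compound 4 (0.43 log units; beyond the scatter) for acetyl in place of 1-hydroxyethyl on an aromatic carbon, a change that removes the hydrogen-bond donor. For the whole group on the amide nitrogen, 3-acetylphenyl in place of 1H-pyrazol-3-yl gives an at least 19-fold lower number from compound 2 to compound 4 (1.28 log units; beyond the scatter) as a bound only. Compound 2 stands at a limit of the assay, not a number: the limit of > 30000 nM in this assay, at which 1 of the 4 values shown sits.

Open, from the compounds shown here alone, is whether the carbonyl itself or the missing hydroxyl hydrogen carries the step. Also open, going by these compounds, is how a carboxylic acid, an amine or a longer acyl chain would read on that aromatic carbon.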